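A few compounds are considered here, and "the series" means these few. Any claim that something is new, unique, unknown or untested is made for them only; others in the source may bear on it.

Measured in a functional assay, with a stated time of 60 min, tested at 0.1 mM; on this read-out higher numbers stand for a stronger effect at the one concentration tested and lower numbers for a weaker effect:
- compound 1 `COC(=O)c1c(O)c2ccccc2n(-c2ccccc2)c1=O`: 9.1%
- compound 2 `NCCNC(=O)c1c(O)c2ccccc2n(-c2ccccc2)c1=O`: 10%
- compound 3 `NCCCCCCNC(=O)c1c(O)c2ccccc2n(-c2ccccc2)c1=O`: 17.5%

Compound 2 sits second highest of the three, with compound 1 nearest: a number 0.9 percentage points higher from compound 1 to compound 2 (within the scatter). Compound 3 is furthest: a number 7.5 percentage points higher from compound 2 to compound 3 (within the scatter). Among the compounds with values here, all three measured steps, including a number 8.4 percentage points higher from compound 1 to compound 3 (within the scatter), fall within the scatter, so no step seen so far changes the read-out reliably.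

Compound 4 `O=C(CCCCC1CCSS1)NCCNC(=O)c1c(O)c2ccccc2n(-c2ccccc2)c1=O` differs from compound 2 in one place: a group of 11 heavy atoms (8 carbon, 1 oxygen, 2 sulfur; one five-membered non-aromatic ring with 2 hetero atoms) in place of a hydrogen atom, on an amine nitrogen. The nearest guide is the step onto the same chain, a number 7.5 percentage points higher from compound 2 to compound 3 (within the scatter), together with the exchanges at the carbonyl carbon, none of which left the scatter. The expected step, a number 3 percentage points higher from compound 2 to compound 4 (within the scatter), is therefore small. Compound 4 is estimated at 13%, within 4% to 26%.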

Compound 4, a percentage reported as activity, at one concentration (the size of the read-out at that concentration, not a potency): 7.8%
The estimate for compound 4 lay 5.2 percentage points above the measured number, and the stated range covers the measured number.
By their numbers in this assay, from the lowest: compounds 4, 1, 2 and 3 (each within the scatter of the next).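

In this assay, a group of 11 heavy atoms, with its five-membered non-aromatic ring with 2 hetero atoms, in place of a hydrogen atom on the amine nitrogen gives a number 2.2 percentage points lower from compound 2 to compound 4 (within the scatter). Within the data shown here, this amine nitrogen can therefore carry a group of this size with no reliable change in the read-out, whereas the earlier steps changed only the chain or the group on the carbonyl carbon. No supporting measurement is available to explain this result.

From the compounds shown here alone, whether an acetyl or benzoyl group on this nitrogen would give a reliable change remains open. Also open, going by these compounds, is what the same group of 11 heavy atoms would do on the amine nitrogen of compound 3.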